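A few compounds are considered here, and "the series" means these few. Any claim that something is new, unique, unknown or untested is made for them only; others in the source may bear on it.

Compound 1: `Cc1cc(-c2ccccc2)n(/C(N)=N/S(=O)(=O)c2cc(C)c(Cl)cc2SCc2cccc3ccccc23)n1` gives 170000 nM in a functional assay on MCF7 cells (Homo sapiens) for cytotoxicity, read by MTT assay, with a stated time of 72 h; on this read-out lower numbers stand for stronger inhibition and higher numbers for weaker inhibition.
Compound 2: `Cc1cc(-c2ccccc2)n(/C(N)=N/S(=O)(=O)c2cc(C)c(Cl)cc2SCc2cccc(Cl)c2)n1` gives 25000 nM in this assay.
Compound 3: `Cc1cc(-c2ccccc2)n(/C(N)=N/S(=O)(=O)c2cc(C)c(Cl)cc2SCc2ccccc2C)n1` gives 80000 nM in this assay.

Among these three, compound 3 stands second highest in this assay: its nearest neighbour is compound 1, which is the change a 2.1-fold lower number from compound 1 to compound 3 (0.33 log units; beyond the scatter), and its furthest is compound 2, which is the change a 3.2-fold higher number from compound 2 to compound 3 (0.51 log units; beyond the scatter). The third measured step, a 6.8-fold lower number from compound 1 to compound 2 (0.83 log units; beyond the scatter), is the largest of the set. All three measured steps swap the whole aromatic group on the saturated chain carbon bound to a sulfur.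

Compound 4, `Cc1cc(-c2ccccc2)n(/C(N)=N/S(=O)(=O)c2cc(C)c(Cl)cc2SCc2ccccc2C(F)(F)F)n1`, differs from compound 3 by trifluoromethyl in place of methyl on an aromatic carbon. Among the compounds with values here, no measured step exchanges one substituent for another on an otherwise unchanged benzyl group, so none bears directly on this change. What the measured steps show is that changes to this part of the shared core move the read-out by modest amounts, none larger than the step from compound 1 to compound 2. For compound 4 in this assay a step of the size a 1.3-fold lower number from compound 3 to compound 4 (0.12 log units; within the scatter) is therefore expected, which may fall within the scatter. Compound 4 is estimated at 60000 nM, with a range from 20000 nM to 200000 nM.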

Compound 4, half-maximal inhibitory concentration: 101000 nM
Compound 4: the middle estimate sits 1.7-fold (0.23 log units) below what was measured; measured number inside the range.
By their numbers in this assay, from the lowest: compound 2; then compounds 3, 4 and 1 (each within the scatter of the next, the first and the last beyond it).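

In this assay, within the data shown here, the exchange of methyl for trifluoromethyl on an aromatic carbon ortho to a large group gives a 1.3-fold higher number from compound 3 to compound 4 (0.10 log units; within the scatter), the first step in which one substituent is exchanged on an otherwise unchanged benzyl group, and the read-out does not separate these two groups at this position. The separation from the 3-chlorophenyl group stays beyond the scatter with 2-(trifluoromethyl)phenyl, at a 4.0-fold higher number from compound 2 to compound 4 (0.61 log units; beyond the scatter), whereas this group is not separated from naphthalen-1-yl, at a 1.7-fold lower number from compound 1 to compound 4 (0.23 log units; within the scatter). The data offer no explanation for these numbers.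

As far as these compounds go, it remains open whether other groups on this same aromatic carbon, such as methoxy, an amine or a carboxylic acid, would also leave the read-out within the scatter of compound 3, and whether methyl and trifluoromethyl would stay inseparable elsewhere on the ring. Also open, from the compounds shown here alone, is what a longer chain in place of the saturated chain carbon bound to a sulfur would do, and whether a chlorine on this same aromatic carbon would give a number nearer to that of compound 2 in this assay.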